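One methyl added to compound 2

The compounds below may be only part of what the source reports. "The series", "measured", "known", "first", "only" and "open" are said of these compounds alone.

Compound 1 `CCCCC/C=C\C/C=C\CCCCCCCc1cc(=O)c2c(O)c(C)c(O)cc2o1` gives > 84100 nM (a limit of the assay)
Compound 2 `CCCC/C=C\CCCCCCCCCc1cc(=O)c2c(O)cc(O)cc2o1` gives 17500 nM

Going by the values given here, in a functional assay on MCF7 cells (Homo sapiens) for antiproliferative activity, read by MTT assay (on this read-out higher numbers stand for weaker inhibition and lower numbers for stronger inhibition), compound 2 gives 17500 nM as the only exact number so far. Compound 1 reaches only > 84100 nM in this assay and that value is a limit of the assay. Compound 3 `CCCC/C=C\CCCCCCCCCc1cc(=O)c2c(O)c(C)c(O)cc2o1` is compound 2 with methyl in place of hydrogen on an aromatic carbon. Among the compounds with values here, no measured pair shows this change alone, so the guide is loose. The expectation rests on compound 1, which carries the same methyl on a different chain, and whose > 84100 nM is a limit. An estimated step of a 2.3-fold higher number from compound 2 to compound 3 (0.36 log units; beyond the scatter) is expected in this assay, towards weaker inhibition and modestly beyond the scatter. For compound 3 the estimated value is 40000 nM, with an expected range from 13000 nM to 100000 nM.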

Compound 3, half-maximal inhibitory concentration: 43200 nM
For compound 3 the middle estimate is 1.1-fold (0.03 log units) below the measured one; low and high end bracket the measured number.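

Going by these compounds alone, with the methyl in place of hydrogen on the aromatic carbon ortho to two hydroxy groups, this assay gives a 2.5-fold higher number from compound 2 to compound 3 (0.39 log units; beyond the scatter), so this single change, seen alone for the first time, weakens inhibition modestly without abolishing it. The change of chain, with the methyl held constant, can be read only as a floor: an at least 1.9-fold lower number from compound 1 to compound 3 (0.28 log units; that floor lies within the scatter). Compound 1 stands at > 84100 nM, which is a limit of the assay, so the full size of that step stays unknown: the limit of > 84100 nM in this assay, at which 1 of the 3 values shown sits.

Methyl is the only group shown at this position, so it remains open whether ethyl, methoxy or chlorine there would shift the value in the same direction. It also remains open how a saturated chain of the same length would compare with the unsaturated chains shown.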